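The source may hold more compounds than are shown below. What is called first, only, known or untested is meant among the compounds shown, and "the series" means these compounds.

Compound 1 `C#CCSc1nc(Nc2ccc(OC)cc2)c(C#N)c(-c2ccccc2)n1` gives 9710 nM in a functional assay on B16-F10 cells (Mus musculus) for inhibition, read by MTT assay, with a stated time of 72 h; a higher number here means a weaker inhibitor, a lower number a stronger inhibitor.
Compound 2 `C#CCSc1nc(Nc2ccc(Cl)cc2)c(C#N)c(-c2ccccc2)n1` gives 19800 nM in this assay.
Compound 3 `COc1ccccc1Nc1nc(SCc2cn(Cc3ccccc3Cl)nn2)nc(-c2ccccc2)c1C#N` gives 7860 nM in this assay.

Compound 3 has the lowest of the three numbers in this assay, but its gap to compound 1 lies within the scatter, so the two cannot be ranked; only compound 2 stands beyond it. Compound 4 `N#Cc1c(Nc2ccccc2)nc(SCc2cn(Cc3ccccc3Cl)nn2)nc1-c1ccccc1` differs from compound 3 by hydrogen in place of methoxy on an aromatic carbon. Among the compounds with values here, the sole measured step that touches a methoxy group, a 2.0-fold higher number from compound 1 to compound 2 (0.31 log units; beyond the scatter), exchanged it for chloro rather than hydrogen and was modest, so it bears on the present change only loosely. A modest shift toward a higher number, or none beyond the scatter, is therefore expected. The expected step is a 1.4-fold higher number from compound 3 to compound 4 (0.15 log units; within the scatter). Compound 4 is estimated at 11000 nM, with a range from 5000 nM to 25000 nM.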

Compound 4, half-maximal inhibitory concentration: 28300 nM
Compound 4: middle estimate off by 2.6-fold (0.41 log units), on the low side; the whole stated range lies below it.
By their numbers in this assay, from the lowest: compounds 3 and 1 (each within the scatter of the next); then compounds 2 and 4 (each within the scatter of the next).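

In this assay the change from 2-methoxyphenyl to phenyl gives a 3.6-fold higher number from compound 3 to compound 4 (0.56 log units; beyond the scatter) and so shows that the methoxy, on an aromatic carbon ortho to a large group, matters to the number in this series. The earlier step only exchanged methoxy for chloro in compounds with a different group on sulfur, whereas here the methoxy is removed outright. Nothing available accounts for this step. Going by these compounds, it remains open whether methoxy is specifically required at this place or whether a hydroxyl, an ethoxy or a fluorine would serve equally. On these data alone, whether the same removal would matter in compound 1 also remains open.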